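A few compounds are considered here, and "the series" means these few. Any claim that something is new, unique, unknown or untested is made for them only; others in the source may bear on it.

For the measured compounds named here, in a functional assay (aorta) for inhibition, with Rattus norvegicus as the target (on this read-out higher numbers stand for weaker inhibition and lower numbers for stronger inhibition), three compounds have numbers so far. Compound 1 `C/N=C(\S)[C@]1(c2cccc(C#N)c2)CCCC[S+]1[O-]` gives 1600 nM, compound 2 `C/N=C(\S)[C@]1(c2ccc3ccccc3c2)CCCC[S+]1[O-]` gives 2000 nM, and compound 3 `CC/N=C(\S)[C@]1(c2cccnc2)CCCC[S+]1[O-]` gives 300 nM. That last number is the lowest of the three, and its gaps to both others lie beyond the scatter. Compound 4 `[O-][S+]1CCCC[C@]1(/C(S)=N/c1ccccc1)c1cccnc1` departs from compound 3 in one place, with phenyl in place of ethyl on a double-bonded nitrogen. Going by the values given here, no measured pair shows a change of this kind, so the expectation is only a judgement. Compound 3 already stands lowest at 300 nM, so a rise is thought more likely than a fall. In this assay the expected step is a 5.0-fold higher number from compound 3 to compound 4 (0.70 log units; beyond the scatter), towards weaker inhibition and beyond the scatter. For compound 4 the estimated value is 1500 nM, with an expected range from 400 nM to 6000 nM.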

Compound 4, concentration for 90% inhibition: > 30000 nM
Compound 4 was reported as a limit (the forecaster's own chance of this, stated with the estimate: 10%); middle value at least 20-fold (1.30 log units) away from the limit.
By their numbers in this assay, from the lowest: compound 3; then compounds 1 and 2 (each within the scatter of the next). At a limit, above all of these: compound 4.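

Compound 4 is reported only as a limit in this assay: the limit of > 30000 nM in this assay, at which 1 of the 4 values shown sits.

Phenyl in place of ethyl on a double-bonded nitrogen gives an at least 100-fold higher number from compound 3 to compound 4 (2.00 log units; beyond the scatter), towards weaker inhibition. This is the only one-place comparison among the compounds shown, and it reveals that changing the group at this position alone can take inhibition out of the measured range.

Going by these compounds, what a propyl chain, a cyclohexyl ring or a benzyl group would give here remains open. For the compounds shown here, the single pair cannot separate the aromatic ring from the larger size of the group.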